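The source may hold more compounds than are shown below. What is called first, only, known or untested is meant among the compounds shown, and "the series" means these compounds.

Compound 1 `CCCCCCn1ccc2cc(/C(C)=C/C(=O)Nc3ccccc3OCCCC(=O)O)ccc21` and compound 2 `CCCCCCCn1ccc2cc(/C(C)=C/C(=O)Nc3ccccc3OCCCC(=O)O)ccc21` share a core and differ by methyl in place of hydrogen on a saturated chain carbon, six bonds along the chain from an aromatic nitrogen. In an assay on Prostate gland for inhibition of steroid 5-alpha-reductase (Rattus norvegicus) (a lower number here means a stronger inhibitor, a higher number a weaker inhibitor), compound 1 gives 77 nM, and compound 2 gives 120 nM, a step of a 1.6-fold higher number from compound 1 to compound 2 (0.19 log units; within the scatter). Compound 3 `CCCC(C)n1ccc2cc(/C(C)=C/C(=O)Nc3ccccc3OCCCC(=O)O)ccc21` differs from compound 1 by 1-methylbutyl in place of hexyl on an aromatic nitrogen. In this assay compound 3 gives 7.8 nM; the steps are a 9.9-fold lower number from compound 1 to compound 3 (0.99 log units; beyond the scatter) and a 15-fold lower number from compound 2 to compound 3 (1.19 log units; beyond the scatter). Compound 4 `CCCC(CC)n1ccc2cc(/C(C)=C/C(=O)Nc3ccccc3OCCCC(=O)O)ccc21` has not been measured. It differs from compound 3 by methyl in place of hydrogen on a saturated chain carbon, two bonds along the chain from an aromatic nitrogen, the same kind of change as that between compound 1 and compound 2, though there the methyl enters six bonds along the chain from the aromatic nitrogen and here two bonds along the chain from it. Because a 1.6-fold higher number from compound 1 to compound 2 (0.19 log units; within the scatter) stayed within the scatter, a similarly small step is expected here, a 1.5-fold higher number from compound 3 to compound 4 (0.19 log units; within the scatter). Compound 4 is accordingly estimated at 12 nM, with 5 nM to 35 nM as the likely range.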

Compound 4, half-maximal inhibitory concentration: 9.3 nM
Compound 4: the middle estimate sits 1.3-fold (0.11 log units) above what was measured, within the range that was stated.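

In this assay, the methyl two bonds along the chain from the aromatic nitrogen gives a 1.2-fold higher number from compound 3 to compound 4 (0.08 log units; within the scatter), which matches the earlier step: the same change on two cores in this assay, a 1.6-fold higher number (0.19 log units; within the scatter) from compound 1 to compound 2 and a 1.2-fold higher number (0.08 log units; within the scatter) from compound 3 to compound 4, 1.3-fold (0.12 log units) apart, within the scatter of two such steps. The 1-ethylbutyl group also keeps the gap to the straight chains, with a 13-fold lower number from compound 2 to compound 4 (1.11 log units; beyond the scatter) and an 8.3-fold lower number from compound 1 to compound 4 (0.92 log units; beyond the scatter). These two pairs show that adding this methyl stayed within the scatter at two places on the chain, but they do not show that it would do so on other cores or at other places.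

The compounds shown leave open how a ring such as cyclohexyl on the aromatic nitrogen would read in this assay. They also leave open what an ester in place of the carboxylic acid would do.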